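From hydroxy to allyl(methyl)amino: working notes on compound 3

The source may report more compounds than this note shows. Statements on the series, on what has been measured and on what is new or still open speak of the compounds shown alone.

Of the compounds shown here, two have numbers so far. In a functional assay on the whole organism for positive allosteric modulation, with Mus musculus as the target (a higher number here means that more compound is needed for the effect, a lower number that less compound is needed), compound 1 (`CCC(=O)N(c1ccc(Cl)c(Cl)c1)C1CCCC1O`) gives 0.4 mg/kg as the lower of the two, and compound 2 (`CCCC(=O)N(c1ccc(Cl)c(Cl)c1)C1CCCC1N(C)C`) gives 2 mg/kg as the higher, a gap beyond the scatter.

Compound 3 (`C=CCN(C)C1CCCC1N(C(=O)CC)c1ccc(Cl)c(Cl)c1`) keeps the core of compound 1 but carries allyl(methyl)amino in place of hydroxy on a saturated ring carbon. Among the compounds with values here, no two measured compounds differ in one place only, so no measured step speaks directly to this change. Within the data shown here, the nearest guide is compound 2 with 2 mg/kg as the only measured compound bearing a substituted amino group in that place. One compound makes a weak guide, so the expectation stays loose. A moderate move toward a higher number is expected, meaning that more compound would be needed. The expected change in this assay is a 3.8-fold higher number from compound 1 to compound 3 (0.57 log units; beyond the scatter) as a rise in dose. For compound 3 the estimated dose is 1.5 mg/kg within an expected range of 0.4 mg/kg to 6 mg/kg for this assay.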

Compound 3, dose for half-maximal effect: 0.2 mg/kg
Estimate against measurement, compound 3: 7.5-fold (0.88 log units) above, and the stated range ends above it.
By their numbers in this assay, from the lowest: compounds 3 and 1 (each within the scatter of the next); then compound 2.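

In this assay the replacement gives a 2.0-fold lower number from compound 1 to compound 3 (0.30 log units; within the scatter), so hydroxy and allyl(methyl)amino cannot be told apart at this position on a saturated ring carbon, next to the ring atom that bears a large group. Within the data shown here, this is the first measured step at this place, and it shows that the number holds when a group of 1 heavy atom and 1 hydrogen-bond donor gives way to one of 5 heavy atoms and 0 hydrogen-bond donors, so the hydroxy hydrogen is not needed for a dose in this range. No measured evidence bears on why the two compounds read alike.

Among these compounds, compound 2 differs from compound 1 and from compound 3 in more than one place, so no step ties its number to the amino group alone, and the effect of that group stays separate from that of the amide chain. Still open, from the compounds shown here alone, is how dimethylamino, a primary amine, or a carboxylic acid would read at this position on the core of compound 1, and whether the double bond of the allyl group matters when compared with a saturated propyl chain.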